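A few compounds are considered here, and "the series" means these few. Any claim that something is new, unique, unknown or untested is made for them only; others in the source may bear on it.

Measured so far in an ADME assay for permeability; on this read-out lower numbers stand for lower permeability and higher numbers for higher permeability:
- compound 1, `CC[C@@H](c1ccccc1)n1nc(C(=O)NC)cc1C(=O)N[C@H]1CC[C@H](O)CC1`: 70 nm/s
- compound 2, `CNC(=O)c1cc(C(=O)N[C@H]2CC[C@H](O)CC2)n([C@@H](C)c2cccc(C)c2)n1`: 110 nm/s
- compound 3, `CNC(=O)c1cc(C(=O)N[C@H]2CC[C@H](OC)CC2)n([C@@H](CO)c2ccccc2)n1`: 39 nm/s

Compound 2 holds the highest of the three numbers in this assay; compound 1 stands nearest to it, and compound 3, which differs from compound 2 in more than one place, stands furthest and is beyond the scatter from it.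

Compound 4, `CNC(=O)c1cc(C(=O)N[C@H]2CC[C@H](O)CC2)n([C@@H](C)c2ccc(C(F)(F)F)cc2)n1`, is not yet measured. It differs from compound 2 in one place: 4-(trifluoromethyl)phenyl in place of 3-methylphenyl on a saturated chain carbon bound to an aromatic nitrogen and a saturated chain carbon. Among the measured compounds shown here, the one measured step at the same place is a 1.6-fold higher number from compound 1 to compound 2 (0.20 log units; within the scatter), and that step stays within the scatter. For the measured compounds named here, no measured step swaps a methyl on the phenyl for a trifluoromethyl, so nothing here speaks for a shift in either direction.

On that basis compound 4 is expected to stay close to compound 2 in this assay, with an estimated step of no change at the digits printed from compound 2 to compound 4 (within the scatter). The estimate for compound 4 is 110 nm/s, with a range from 55 nm/s to 230 nm/s.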

Compound 4, apparent permeability: 270 nm/s
Beside the measured number, compound 4's estimate is 2.5-fold (0.39 log units) below it; the measured number lies above the stated range.
By their numbers in this assay, from the lowest: compounds 3, 1 and 2 (each within the scatter of the next, the first and the last beyond it); then compound 4.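

In this assay, the group on the saturated chain carbon bound to an aromatic nitrogen and a saturated chain carbon can now be seen to move the number beyond the scatter: 4-(trifluoromethyl)phenyl in place of 3-methylphenyl gives a 2.5-fold higher number from compound 2 to compound 4 (0.39 log units; beyond the scatter). Among the compounds shown here, the only earlier step at this place, a 1.6-fold higher number from compound 1 to compound 2 (0.20 log units; within the scatter), stayed within the scatter, so the earlier compounds did not show this position responding. No supporting data bear on why this change gives a step of this size.

The two groups differ both in the substituent and in where it stands on the phenyl, so the compounds shown do not separate these two changes. Also open, on these data alone, is how a phenyl carrying a nitrile or an amine at this place would read in this assay.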